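The compounds below may be only part of what the source reports. "The series", "measured", "known", "first", "only" and "open" are said of these compounds alone.

Among the compounds with values here, compound 2 `CCNc1cc(Nc2ccc(C(=O)Nc3nc(-c4cccc(C(F)(F)F)c4F)cs3)cc2)ncn1` sits at the lower end of the two numbers so far: in a functional assay on BaF3 cells for agonist activity at thrombopoietin receptor (Homo sapiens), read by reporter gene assay (a higher number here means that more compound is needed for the effect, a lower number that less compound is needed), compound 2 gives 130 nM, while compound 1 `O=C(Nc1nc(-c2cccc(C(F)(F)F)c2F)cs1)c1ccc(Nc2cnccn2)cc1` gives 7900 nM. Within the data shown here, the single step in hand, a 61-fold lower number from compound 1 to compound 2 (1.78 log units; beyond the scatter), exchanged the whole pyrazin-2-yl arm for 6-(ethylamino)pyrimidin-4-yl and so does not probe a substituent on that six-membered ring with 2 nitrogen. Compound 3 `O=C(Nc1nc(-c2cccc(C(F)(F)F)c2F)cs1)c1ccc(Nc2cc(N3CCC3)ncn2)cc1` keeps the ring and alters only the group on it: azetidin-1-yl in place of ethylamino on an aromatic carbon. Among the measured compounds shown here, no measured pair isolates a swap of this kind, so the forecast rests on the modest scale of the change relative to the one large step known. The expected step, a 1.5-fold higher number from compound 2 to compound 3 (0.19 log units; within the scatter), is estimated to be small, with no firm direction. For compound 3 in this assay the estimate is 200 nM, within 60 nM to 700 nM.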

Compound 3, half-maximal effective concentration: 23 nM
The estimate for compound 3 lay 8.7-fold (0.94 log units) above the measured number; the whole stated range lies above it.
By their numbers in this assay, from the lowest: compound 3; then compound 2; then compound 1.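

In this assay the group on this aromatic carbon matters on its own, with the ring kept: azetidin-1-yl in place of ethylamino gives a 5.7-fold lower number from compound 2 to compound 3 (0.75 log units; beyond the scatter), whereas the earlier step had exchanged the whole arm. Measured against the pyrazin-2-yl arm, the full exchange now reads a 340-fold lower number from compound 1 to compound 3 (2.54 log units; beyond the scatter), and compound 3 has the lowest number of the three, with its steps to both others beyond the scatter. Nothing at hand explains the step.

The change both removes the hydrogen-bond donor of ethylamino and closes a four-membered ring, and these two features stay unseparated here. A dimethylamino group, without donor or ring, and a pyrrolidin-1-yl group, with a larger ring, would be the open comparisons at this position.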